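A few compounds are considered here, and "the series" means these few. Any claim that something is new, unique, unknown or untested is made for them only; others in the source may bear on it.

Compound 1 `CN1CCN(c2ccc(C3=NN(S(C)(=O)=O)C(c4ccc(N(C)C)cc4)C3)cc2)CC1`: -18.5% in a functional assay on HCC1806 cells (Homo sapiens) for inhibition, read by sulforhodamine B assay, tested at 10 uM; on this read-out higher numbers stand for more inhibition at the one concentration tested (going by the name of the read-out) and lower numbers for less inhibition
Compound 2 `CN1CCN(c2ccc(C3=NN(S(=O)(=O)c4ccc(F)cc4)C(c4ccc(N(C)C)cc4)C3)cc2)CC1`: 92.3%
Compound 3 `CN1CCN(c2ccc(C3=NN(S(=O)(=O)c4ccc(OC(F)(F)F)cc4)C(c4ccc(N(C)C)cc4)C3)cc2)CC1`: 70.8%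

Compound 2 stands highest of these three numbers; compound 3 comes nearest, a number 21.5 percentage points lower from compound 2 to compound 3 (beyond the scatter), and compound 1 lies furthest, a number 110.8 percentage points higher from compound 1 to compound 2 (beyond the scatter). Compound 4 `CN(C)c1ccc(C2CC(c3ccc(-n4cncn4)cc3)=NN2S(=O)(=O)c2ccc(F)cc2)cc1` differs from compound 2 in one place: 1H-1,2,4-triazol-1-yl in place of 4-methylpiperazin-1-yl on an aromatic carbon. Within the data shown here, the measured steps all concern the group on the sulfonyl sulfur or the fluoro on its aromatic carbon, as in a number 89.3 percentage points higher from compound 1 to compound 3 (beyond the scatter); none touches the 4-methylpiperazin-1-yl group, so no measured step bears directly on this change. Compound 4 is therefore expected to keep much of the inhibition of compound 2, with wide uncertainty, giving an expected step of a number 22.3 percentage points lower from compound 2 to compound 4 (beyond the scatter). Compound 4 is estimated at 70%, between 30% and 95%.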

Compound 4, a percentage reported as inhibition, at one concentration (the size of the read-out at that concentration, not a potency): 24.1%
For compound 4 the middle estimate is 45.9 percentage points above the measured one; the whole stated range lies above it.
By their numbers in this assay, from the lowest: compound 1; then compound 4; then compound 3; then compound 2.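

With 4-fluorophenyl kept on the sulfonyl sulfur, placing 1H-1,2,4-triazol-1-yl instead of 4-methylpiperazin-1-yl on the aromatic carbon gives a number 68.2 percentage points lower from compound 2 to compound 4 (beyond the scatter) in this assay. The earlier steps shown here changed only the sulfonyl side, whereas this one shows that the group at this second place can also shift the result by a large amount. No available evidence gives a reason for this drop.

Going by these compounds, it remains open whether other groups here, such as morpholin-4-yl or dimethylamino, would keep the inhibition. The same exchange could also behave differently with 4-(trifluoromethoxy)phenyl on the sulfonyl sulfur.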